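Rhamnoside diacid series: chain lengthening in the cell assay

A few compounds are considered here, and "the series" means these few. Any claim that something is new, unique, unknown or untested is made for them only; others in the source may bear on it.

Measured so far:
compound 1 `CC1OC(OC2CCCCC2OCCCCCC(C(=O)O)C(=O)O)C(O)C(O)C1O` — > 5000000 nM
compound 2 `CC1OC(OC2CCCCC2OCCCCCCC(C(=O)O)C(=O)O)C(O)C(O)C1O` — > 5000000 nM
compound 3 `CC1OC(OC2CCCCC2OC(=O)NCCC(C(=O)O)C(=O)O)C(O)C(O)C1O` — 3400000 nM

The read-out is a functional assay on HL-60 cells (Homo sapiens) for inhibition; a lower number here means a stronger inhibitor, a higher number a weaker inhibitor. Compound 1 reaches only a limit of this assay, > 5000000 nM. Compound 2 likewise reaches only a limit, > 5000000 nM. Among the measured compounds shown here, compound 3 is the one compound with a number, 3400000 nM. The step from compound 1 to compound 2 is a step that the two limits leave unreadable from compound 1 to compound 2; the change is 2,2-dicarboxyethyl in place of dicarboxymethyl on a saturated chain carbon, five bonds along the chain from an oxygen on a saturated carbon, and its size cannot be read, since both values sit at the limit of > 5000000 nM in this assay, at which 2 of the 3 values shown sit.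

Compound 4 `CC1OC(OC2CCCCC2OC(=O)NCCCC(C(=O)O)C(=O)O)C(O)C(O)C1O` is not yet measured. It differs from compound 3 by 2,2-dicarboxyethyl in place of dicarboxymethyl on a saturated chain carbon, two bonds along the chain from an amide-type nitrogen. This is the same kind of change as that from compound 1 to compound 2, but the surroundings differ: there the place was five bonds along the chain from an oxygen on a saturated carbon, here it is two bonds along the chain from an amide-type nitrogen. The difference between the core of compound 1 and the core of compound 3 is not broken down here.

The measured step gives no size to carry over. Compound 4 is therefore expected to lie near compound 3, with a step of about a 1.3-fold higher number from compound 3 to compound 4 (0.12 log units; within the scatter), resting only on compound 3 at 3400000 nM. The expected value for compound 4 is 4500000 nM, between 2500000 nM and 8000000 nM.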

Compound 4, half-maximal inhibitory concentration: 1000000 nM
For compound 4 the middle estimate is 4.5-fold (0.65 log units) above the measured one; the measured number lies below the stated range.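

In this assay, 2,2-dicarboxyethyl in place of dicarboxymethyl, on a saturated chain carbon two bonds along the chain from an amide-type nitrogen, gives a 3.4-fold lower number from compound 3 to compound 4 (0.53 log units; beyond the scatter). The same change on the core of compound 1 cannot be read, since compound 1 and compound 2 both stand at a limit and not at a number: the limit of > 5000000 nM in this assay, at which 2 of the 4 values shown sit. The series therefore holds one readable instance of this change, which shows that it can lower the number on the core of compound 3, with compound 4 at 1000000 nM, but does not show whether a step of this size carries over to the core of compound 1.

Open, from the compounds shown here alone, is whether the step continues along the chain on the core of compound 3, with 3,3-dicarboxypropyl or 4,4-dicarboxybutyl in place of 2,2-dicarboxyethyl. Also open, going by these compounds, is how a chain ending in a single carboxylic acid would compare with the paired acids on this core.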